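The compounds below may be only part of what the source reports. "The series", "measured", "known", "first", "only" and "open" are said of these compounds alone.

Working notes on the series. The shared core is varied at one saturated ring carbon. Compound 1 `C#CC[C@@H]1O[C@H](COCc2ccccc2)[C@@H](OCc2ccccc2)[C@H](OCc2ccccc2)[C@H]1O` is recorded in a functional assay on HL-60 cells (Homo sapiens) for antiproliferative activity, read by MTT assay (on this read-out higher numbers stand for weaker inhibition and lower numbers for stronger inhibition), as "not active" (no number reported). Compound 2 `O[C@@H]1[C@@H](OCc2ccccc2)[C@H](OCc2ccccc2)[C@@H](COCc2ccccc2)O[C@H]1CC1CCCCC1` gives 4100 nM in this assay. Compound 3 `CC(C)(C)C[C@@H]1O[C@H](COCc2ccccc2)[C@@H](OCc2ccccc2)[C@H](OCc2ccccc2)[C@H]1O` is recorded in this assay as "not active" (no number reported); it thus stands with compound 1 as one of two entries without a number, and compound 2 alone carries a value. Compound 4 `O[C@H]1CO[C@H](COCc2ccccc2)[C@@H](OCc2ccccc2)[C@@H]1OCc1ccccc1` removes the substituent altogether: hydrogen in place of neopentyl on a saturated ring carbon. Compound 3 gives no number, so no step size can be set out, and the change is expected to bring no gain beyond the scatter. Compound 4 is expected to show 30000 nM in this assay, within 8000 nM to 100000 nM, with a high chance of no number being reported.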

Compound 4, half-maximal inhibitory concentration: "not active" (no number reported)
Nothing numeric was reported for compound 4, and the estimate cannot be compared.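

Compound 3 and compound 4 both stand without a number, so no step can be read between them. The compounds shown leave open what sets compound 2 apart from the other three. No evidence bears on this result.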